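Moving a halogen around the ring: bromo for fluoro

The source may report more compounds than this note shows. Statements on the series, on what has been measured and on what is new or still open speak of the compounds shown alone.

Compound 1 `O=C(N/N=C/c1cccc(F)c1)c1cnccn1`: 49%
Compound 2 `O=C(N/N=C/c1ccc(F)cc1)c1cnccn1`: 78%
Compound 3 `O=C(N/N=C/c1cccc(Br)c1)c1cnccn1`: 100%

Three compounds were tested in an ADME assay on J774 cells (Mus musculus) for cytotoxicity, read by MTT assay, with a stated time of 48 h, tested at 50 ug/mL; a higher number here means a weaker effect of the compound at the concentration tested, a lower number a stronger effect. Compound 1 gives 49%, and exchanging its halogen, (bromo in place of fluoro on an aromatic carbon), leads to compound 3, a step of a number 51 percentage points higher from compound 1 to compound 3 (beyond the scatter). Compound 2 shares the same atoms as compound 1 joined differently; the difference between the two cores is not broken down here. In this assay compound 2 gives 78%.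

Compound 4 `O=C(N/N=C/c1ccc(Br)cc1)c1cnccn1` is not yet measured. It arises from compound 2 by the same kind of change, (bromo in place of fluoro on an aromatic carbon), though here the place is para to a large group rather than meta to it. Because the earlier step of a number 51 percentage points higher from compound 1 to compound 3 (beyond the scatter) was large, a rise is expected, giving a number 17 percentage points higher from compound 2 to compound 4 (beyond the scatter). Compound 4 is estimated at 95%, between 80% and 105%.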

Compound 4, a percentage reported as activity, at one concentration (the size of the read-out at that concentration, not a potency): 100%
The estimate for compound 4 lay 5 percentage points below the measured number; measured number inside the range.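

In this assay, bromo in place of fluoro gives a number 22 percentage points higher from compound 2 to compound 4 (beyond the scatter), so the number rises on both cores, but not by the same amount: the same change on two cores in this assay, a number 51 percentage points higher (beyond the scatter) from compound 1 to compound 3 and a number 22 percentage points higher (beyond the scatter) from compound 2 to compound 4, 29 percentage points apart, beyond the scatter of two such steps

The direction carried over from one core to the other and the size did not, and the two bromo compounds end level, with compound 3 at 100% and compound 4 at 100%. These steps do not show why the size differs, and two cores set no rule for any other core.

As far as these compounds go, only fluoro and bromo appear on the ring here, so what chloro, a methoxy group, an amine or a carboxylic acid would do in these places stays open. From the compounds shown here alone, how the compounds would read at any other concentration also stays open.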